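Swapping one ring on a short-lived compound

A few compounds are considered here, and "the series" means these few. Any claim that something is new, unique, unknown or untested is made for them only; others in the source may bear on it.

Measured in an ADME assay on microsomes from liver (Mus musculus) for metabolic stability, read by LC-MS, using NADPH, with stated times of 15 min and 60 min, tested at 4.6 uM; on this read-out lower numbers stand for a shorter-lived compound and higher numbers for a longer-lived compound:

Compound 1 `CC(C)CNC(=O)n1c(=O)oc2c(C3CCN(C)CC3)cccc21` gives 0.5 h
Compound 2 `CN1CCN(c2ccc3c(c2)oc(=O)n3C(=O)NCCCCc2ccccc2)C(=O)C1` gives < 0.0834 h
Compound 3 `CC(C)CNC(=O)n1c(=O)oc2cc(C3CCCCN3C)ccc21` gives 0.25 h

Compound 2 stands at the limit of < 0.0834 h in this assay, at which 1 of the 3 values shown sits. Its reading of < 0.0834 h is a limit of the assay and not a number, so its true half-life is not known.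

Compound 4 `CN1CCC(c2ccc3c(c2)oc(=O)n3C(=O)NCCCCc2ccccc2)CC1` is not yet measured. Within the data shown here, it keeps the core and the 4-phenylbutyl chain of compound 2, and only one group changes: 1-methylpiperidin-4-yl in place of 4-methyl-2-oxopiperazin-1-yl on an aromatic carbon.

Compound 1 carries the same 1-methylpiperidin-4-yl group and gives 0.5 h, but that group sits elsewhere on the core and the side chain differs, so it is only a loose guide. A small upward move, not clearly beyond the usual scatter, is expected for an at least 1.0-fold higher number from compound 2 to compound 4 (0.03 log units; that floor lies within the scatter) in this assay.

The estimated half-life of compound 4 is 0.09 h, with an expected range from 0.05 h to 0.25 h.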

Compound 4, half-life: 0.667 h
Beside the measured number, compound 4's estimate is 7.4-fold (0.87 log units) below it, outside the stated range (above it).
By their numbers in this assay, from the lowest: compounds 3, 1 and 4 (each within the scatter of the next, the first and the last beyond it). At a limit, below all of these: compound 2.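

In this assay, replacing 4-methyl-2-oxopiperazin-1-yl with 1-methylpiperidin-4-yl on this aromatic carbon, with the shared core and the 4-phenylbutyl chain kept, gives an at least 7.9-fold higher number from compound 2 to compound 4 (0.90 log units; beyond the scatter). Compound 2 stands at a limit of the assay, not at a number: the limit of < 0.0834 h in this assay, at which 1 of the 4 values shown sits. Among these compounds, this is the only comparison here in which just one place differs, and it shows that the group at this place can by itself move the half-life beyond the usual scatter.

The compounds shown do not separate the parts of this change, so a plain piperazine without the carbonyl, or a morpholine, at this place remains an open case. Also open, from the compounds shown here alone, is whether a shorter chain in place of the 4-phenylbutyl chain would alter the half-life with the 1-methylpiperidin-4-yl group kept.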